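Amide-aryl change in a cytotoxicity series

The source may hold more compounds than are shown below. What is called first, only, known or untested is meant among the compounds shown, and "the series" means these compounds.

Measured so far:
compound 1, `COc1ccc(NC(=O)c2cccc(/C=C3\CC(=O)N(c4ccc(C)cc4)C3=O)c2)cc1`, 93000 nM
compound 2, `COc1ccc(NC(=O)c2cccc(/C=C3\CC(=O)N(c4ccccc4)C3=O)c2)c(C)c1`, > 100000 nM

In an ADME assay on SW480 cells (Homo sapiens) for cytotoxicity, read by MTT assay, with a stated time of 72 h (a lower number here means a stronger inhibitor, a higher number a weaker inhibitor), compound 1 gives 93000 nM. Compound 2 gives only a limit of the assay in this assay, > 100000 nM. Both measured compounds sit at the weak end of the scale, and compound 2 stands at the limit itself, as noted in the limit of > 100000 nM in this assay, at which 1 of the 2 values shown sits. For the measured compounds named here, no step between measured compounds that differ in one place is available here.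

Compound 3, `O=C(Nc1ccc(OC(F)F)cc1)c1cccc(/C=C2\CC(=O)N(c3ccccc3)C2=O)c1`, is the next compound to be measured in this assay. It differs from compound 2 by 4-(difluoromethoxy)phenyl in place of 4-methoxy-2-methylphenyl on an amide-type nitrogen. With nothing measured across this change, and compound 2 known only as a limit, the expected step of a number no higher from compound 2 to compound 3 (the limit leaves the size open) is none beyond the scatter. Compound 3 is expected near the limit, at an estimated 100000 nM with a range from 40000 nM to 300000 nM, and it may again be reported only as a limit.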

Compound 3, half-maximal inhibitory concentration: > 100000 nM
Compound 3 was reported as a limit; the forecaster's own chance of this, stated with the estimate: 55%; the middle value lies on the limit itself.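

No step can be read from compound 2 to compound 3, since both are reported only as limits of the assay: the limit of > 100000 nM in this assay, at which 2 of the 3 values shown sit.
On these data alone, what stays open is how 4-(difluoromethoxy)phenyl and 4-methoxy-2-methylphenyl on an amide-type nitrogen compare in this assay, as neither compound has a value beyond its limit.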